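The compounds below may be only part of what the source reports. "The series", "measured", "known", "first", "only" and "open" are said of these compounds alone.

Compound 1 `COc1cc2c(cc1OC)C(c1ccc(Cl)cc1)=NNC(=O)C2` – 102 umol/kg
Compound 2 `COc1cc2c(cc1OC)C(c1ccc(Br)cc1)=NN(C)C(=S)C2` – 105 umol/kg

Of the compounds shown here, two have been tested in a functional assay on the whole organism with Mus musculus as the target; on this read-out lower numbers stand for an effect already at smaller amounts and higher numbers for an effect only at larger amounts of compound. Compound 1 gives 102 umol/kg in this assay, and compound 2, which differs from it in several places at once, gives 105 umol/kg. These two numbers lie within the usual scatter of repeated measurements, so on the figures shown compound 1 and compound 2 cannot be told apart. Going by the values given here, no pair of measured compounds differs in only one place, so no single-change step has been measured so far.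

Compound 3 `COc1cc2c(cc1OC)C(c1ccc(Br)cc1)=NNC(=O)C2` has not yet been measured. It differs from compound 1 in one place: bromo in place of chloro on an aromatic carbon. A change of one halogen for another at the same position is a small alteration of the molecule, and nothing in the measured numbers points to a shift in either direction. The step of a 1.0-fold lower number from compound 1 to compound 3 (0.01 log units; within the scatter) is therefore expected to stay within the scatter, because compound 2 with a bromo group gives 105 umol/kg. In this assay compound 3 is expected to give 100 umol/kg, within a range of 50 umol/kg to 200 umol/kg.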

Compound 3, dose for half-maximal effect: 110 umol/kg
The estimate for compound 3 lay 1.1-fold (0.04 log units) below the measured number, and the stated range covers the measured number.
By their numbers in this assay, from the lowest: compounds 1, 2 and 3 (each within the scatter of the next).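

In this assay, going by these compounds alone, the exchange of 4-chlorophenyl for 4-bromophenyl gives the first step in which only one place differs: a 1.1-fold higher number from compound 1 to compound 3 (0.03 log units; within the scatter). On an aromatic carbon para to a large group, bromo in place of chloro therefore leaves the two compounds indistinguishable on this read-out, something the comparison of compound 1 with compound 2 could not show, since those two differ in several places at once. No measurement at hand speaks to why the two halogens read alike.

Going by these compounds, only these two halogens appear at this position, so it remains open whether the read-out would stay in the same range with a very different group there, such as an amine, a carboxylic acid or a longer chain. The compounds shown also offer no single-change step anywhere else on the molecule, so what the carbonyl, the amide hydrogen or the two methoxy groups each contribute cannot yet be read from these numbers.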